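This account rests on a few compounds, and the source may have more. Where it says the series, first, only, none or still open, it means among the compounds named here.

Measured so far in a functional assay on MV4-11 cells (Homo sapiens) for antiproliferative activity, with a stated time of 6 days, tested at 1.56 uM; on this read-out lower numbers stand for a weaker effect and higher numbers for a stronger effect at the one concentration tested:
compound 1 `CNC(=O)N1CCCc2ccc(NC(=O)c3ccc(-c4cnn(C)c4)cc3)cc21`: 77.4%
compound 2 `CNC(=O)N1CCCc2ccc(NC(=O)c3ccc(-c4ccn(C(C)=O)n4)cc3)cc21`: 35.8%
compound 3 `CNC(=O)N1CCCc2ccc(NC(=O)c3cccc(-c4cc[nH]n4)c3)cc21`: 27.3%

Compound 2 stands second highest of the three numbers in this assay; compound 3 lies within the scatter of it, compound 1 beyond it. Going by the values given here, the only measured step at this position is a number 41.6 percentage points lower from compound 1 to compound 2 (beyond the scatter), a large drop. Compound 4 `CNC(=O)N1CCCc2ccc(NC(=O)c3ccc(-c4cccnc4)cc3)cc21` differs from compound 2 as follows: pyridin-3-yl in place of 1-acetyl-1H-pyrazol-3-yl on an aromatic carbon. Pyridin-3-yl has not been measured in this series, so that step bears on the change only loosely, showing that the group at this carbon can move the read-out a long way. Given that compound 1 gives 77.4% with a different small heteroaryl here, a gain is expected for compound 4, a number 22.2 percentage points higher from compound 2 to compound 4 (beyond the scatter), though its size is uncertain. Compound 4 is estimated at 58%, range 35% to 80%.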

Compound 4, a percentage reported as inhibition, at one concentration (the size of the read-out at that concentration, not a potency): 62.5%
Estimate against measurement, compound 4: 4.5 percentage points below; the measured number falls inside the stated range.
By their numbers in this assay, from the lowest: compounds 3 and 2 (each within the scatter of the next); then compound 4; then compound 1.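

In this assay the change to pyridin-3-yl reads as a number 26.7 percentage points higher from compound 2 to compound 4 (beyond the scatter) when it replaces 1-acetyl-1H-pyrazol-3-yl and as a number 14.9 percentage points lower from compound 1 to compound 4 (beyond the scatter) when it replaces 1-methyl-1H-pyrazol-4-yl, so a six-membered aromatic ring at this carbon keeps the read-out between those of the two pyrazoles. Compound 1 and compound 2, both with five-membered rings, fall on either side of compound 4, so ring size alone does not order these numbers. Nothing at hand explains these differences. Open, going by these compounds, is how an amine such as morpholin-4-yl or a carboxylic acid at this carbon would read.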